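This account rests on a few compounds, and the source may have more. Where it says the series, first, only, none or still open, it means among the compounds named here.

Working notes on the series. Among the compounds with values here, in a physicochemical assay for solubility, in phosphate buffer, with a stated time of 24 h, at pH 7.4 (a lower number here means a less soluble compound, a higher number a more soluble compound), compound 1 `Cc1oc(C(=O)NS(=O)(=O)c2ccccc2)cc1COc1ccc(-c2ccccc2)cc1` gives 2 ug/mL and stands lowest of the two numbers so far. Compound 2 `COc1ccc(-c2ccc(OCc3cc(C(=O)NS(=O)(=O)c4ccc(C)cn4)oc3C)cc2)cc1` gives 5 ug/mL in this assay and is the nearest neighbour, higher by a gap beyond the scatter. Within the data shown here, no two measured compounds differ in one place only, so no measured step speaks directly to the next change.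

Compound 3 `Cc1oc(C(=O)NS(=O)(=O)c2ccccc2)cc1COc1ccc(-c2ccc(OC(F)F)cc2)cc1` is compound 1 with difluoromethoxy in place of hydrogen on an aromatic carbon, para to a large group, so that phenyl becomes 4-(difluoromethoxy)phenyl. In counted terms difluoromethoxy in place of hydrogen on an aromatic carbon is the whole difference.

Among the measured compounds shown here, with no step to lean on, the expectation rests on the starting point of compound 1 at 2 ug/mL in this assay and on the added group alone. No change beyond the scatter is expected, with a slight lean toward a lower number. The estimated 1.4-fold lower number from compound 1 to compound 3 (0.15 log units; within the scatter) is expected to stay within the scatter. For compound 3 the estimated value is 1.4 ug/mL with an expected range of 0.5 ug/mL to 3.5 ug/mL on measurement.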

Compound 3, solubility: < 0.6 ug/mL
Compound 3 was reported as a limit (the forecaster's own chance of this, stated with the estimate: 15%); middle value at least 2.3-fold (0.36 log units) from the limit.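

Compound 3 reads < 0.6 ug/mL in this assay, and this is a limit of the assay, not a number. At the one place that differs, para to a large group, difluoromethoxy in place of hydrogen on an aromatic carbon comes with an at least 3.3-fold lower number from compound 1 to compound 3 (0.52 log units; beyond the scatter), the first step in the series that can be read, and its full size remains unknown: the limit of < 0.6 ug/mL in this assay, at which 1 of the 3 values shown sits. This place is therefore not silent in this assay, and the only group shown there on the core of compound 1 moves the number down by more than the scatter.

From the compounds shown here alone, whether that fall belongs to difluoromethoxy itself or would follow any group at this place stays open, and a hydroxyl, an amine or a carboxylic acid on the same aromatic carbon would help separate the two readings. Going by these compounds, compound 1 differs from compound 2 in more than one place, so compound 2 at 5 ug/mL adds nothing to this step, and how the change would behave on the core of compound 2 also remains open.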